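Cytotoxicity notes on a triazole-linked hydrazone series

The source may hold more compounds than are shown below. What is called first, only, known or untested is meant among the compounds shown, and "the series" means these compounds.

Measured compounds:
- compound 1, `CC(=O)C[C@H]1O[C@@H](On2cc(CN3C(=O)/C(=N\Nc4ccc(C#N)cc4)c4ccccc43)nn2)[C@H](OC(C)=O)[C@@H](OC(C)=O)[C@H]1OC(C)=O`: 75500 nM
- compound 2, `CC(=O)C[C@H]1O[C@@H](On2cc(CN3C(=O)/C(=N\Nc4ccc(F)cc4)c4ccccc43)nn2)[C@H](OC(C)=O)[C@@H](OC(C)=O)[C@H]1OC(C)=O`: 78600 nM
- compound 3, `CC1(C)O[C@H]2O[C@H](Cn3cc(CN4C(=O)/C(=N\Nc5ccc(C#N)cc5)c5ccccc54)nn3)[C@H](O)[C@H]2O1`: 105000 nM

In an ADME assay on Vero cells (Chlorocebus sabaeus) for cytotoxicity, read by fluorescence and resazurin assay, with a stated time of 3 days (a higher number here means that more compound is tolerated, a lower number that less compound is tolerated), compound 1 gives 75500 nM and compound 2 gives 78600 nM. The two share a core and differ by fluoro in place of cyano on an aromatic carbon. The step is a 1.0-fold higher number from compound 1 to compound 2 (0.02 log units; within the scatter); the two numbers show no separation of note.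

Compound 3 carries a different core, with the same cyano-bearing aryl hydrazone. The difference between the core of compound 1 and the core of compound 3 is not broken down here. In this assay compound 3 gives 105000 nM, a value within the scatter of both compound 1 and compound 2, so the three measured compounds are not distinguished by this readout.

Compound 4, `CC1(C)O[C@H]2O[C@H](Cn3cc(CN4C(=O)/C(=N\Nc5ccc(F)cc5)c5ccccc54)nn3)[C@H](O)[C@H]2O1`, is not yet measured. It differs from compound 3 by fluoro in place of cyano on an aromatic carbon, the same change as that from compound 1 to compound 2, made on the core of compound 3. Since the earlier step, a 1.0-fold higher number from compound 1 to compound 2 (0.02 log units; within the scatter), left the number essentially unchanged, compound 4 is expected to sit close to compound 3 in this assay, with an expected step of a 1.0-fold higher number from compound 3 to compound 4 (0.01 log units; within the scatter). Among the compounds with values here, the estimate for compound 4 is 108000 nM, with an expected range from 60000 nM to 200000 nM; this rests only on the single earlier pair and on the value of compound 3, 105000 nM, so a wide range is kept.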

Compound 4, half-maximal cytotoxic concentration: 83800 nM
Estimate against measurement, compound 4: 1.3-fold (0.11 log units) above; the range from low to high includes it.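

In this assay, the change from 4-cyanophenyl to 4-fluorophenyl on the second core gives a 1.3-fold lower number from compound 3 to compound 4 (0.10 log units; within the scatter), and this step does not differ from the one seen on the first core: the same change on two cores in this assay, a 1.0-fold higher number (0.02 log units; within the scatter) from compound 1 to compound 2 and a 1.3-fold lower number (0.10 log units; within the scatter) from compound 3 to compound 4, 1.3-fold (0.12 log units) apart, within the scatter of two such steps. Within this readout, then, the change carries from one core to the other without a separation between the two steps, and on neither core does it move the number beyond the scatter. This does not show that the change is without consequence across the series, as the result rests on two matched pairs on two cores, both with small steps, so it gives no test of transfer for a change that moves the number clearly, and it says nothing about a third core or any other readout.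

Still open, on these data alone, is whether a different group on the same aromatic carbon, such as an amine, a carboxylic acid or a longer alkyl chain, would give a step beyond the scatter in this assay, and whether such a step would then carry between the two cores. Also open, as far as these compounds go, is what the difference between the two cores contributes on its own, as that difference has not been broken down into single changes.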